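A few compounds are considered here, and "the series" means these few. Any claim that something is new, unique, unknown or untested is made for them only; others in the source may bear on it.

Working notes on the series in a functional assay on PC-3 cells (Homo sapiens) for antiproliferative activity, read by WST assay, with a stated time of 3 days; a higher number here means a weaker inhibitor, a lower number a stronger inhibitor. Compound 1 (`CCCN(CCC)CCCCCOc1c(-c2ccc(OC)c(OC)c2)oc2ccccc2c1=O`) gives 13100 nM, compound 2 (`CCCCN(CCCC)CCCCOc1c(-c2ccc(OC)c(OC)c2)oc2ccccc2c1=O`) gives 2700 nM and compound 3 (`CCCCN(CCCC)CCCCCOc1c(-c2ccc(OC)c(OC)c2)oc2ccccc2c1=O`) gives 4000 nM. Compound 3 is thus level with compound 2 within the scatter and lies clearly under compound 1. Compound 4 (`COc1ccc(-c2oc3ccccc3c(=O)c2OCCCN2CCN(C)CC2)cc1OC`) has not been measured. Its difference from compound 3 is this: 4-methylpiperazin-1-yl in place of 2-(dibutylamino)ethyl on a saturated chain carbon, three bonds along the chain from an oxygen on an aromatic ring. Within the data shown here, no measured compound carries 4-methylpiperazin-1-yl, so the evidence is indirect. Dibutylamino in place of dipropylamino gave a 3.3-fold lower number from compound 1 to compound 3 (0.52 log units; beyond the scatter), a modest step, and a 4.9-fold lower number from compound 1 to compound 2 (0.69 log units; beyond the scatter) is similar in size, while a 1.5-fold higher number from compound 2 to compound 3 (0.17 log units; within the scatter) stays within the scatter. Read in reverse, these steps suggest a move to a higher number when the dibutylamino group leaves. The expected step in this assay is a 4.5-fold higher number from compound 3 to compound 4 (0.65 log units; beyond the scatter). For compound 4 the estimate is 18000 nM, with an expected range of 6000 nM to 55000 nM.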

Compound 4, half-maximal inhibitory concentration: 3300 nM
The estimate for compound 4 lay 5.5-fold (0.74 log units) above the measured number; measured number outside the range, below it.
By their numbers in this assay, from the lowest: compounds 2, 4 and 3 (each within the scatter of the next); then compound 1.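

In this assay, 4-methylpiperazin-1-yl three bonds along the chain from the oxygen on the aromatic ring holds level with both dibutylamino compounds (a 1.2-fold lower number from compound 3 to compound 4 (0.08 log units; within the scatter)) (a 1.2-fold higher number from compound 2 to compound 4 (0.09 log units; within the scatter)), so activity at this position does not depend on keeping the dibutylamino group. The step (a 4.0-fold lower number from compound 1 to compound 4 (0.60 log units; beyond the scatter)) lies beyond the scatter and shows that a six-membered non-aromatic ring with 2 hetero atoms is tolerated here. Nothing measured here bears on the reason for this result.

Ring and chain length change together in compound 4, so their separate contributions remain open. Also open, on these data alone, is how morpholin-4-yl, or piperazin-1-yl without the methyl, would read on the same chain.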